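The compounds below may be only part of what the source reports. "The series", "measured", "known", "first", "only" and "open" are said of these compounds alone.

Among the measured compounds shown here, in a functional assay on HCT-116 cells (Homo sapiens) for cytotoxicity, read by MTT assay, with a stated time of 72 h (a higher number here means a weaker inhibitor, a lower number a stronger inhibitor), compound 1 (`COc1ccc(S(=O)(=O)c2nc3ccccc3nc2Nc2ccc(N)cc2)cc1`) gives 6300 nM and compound 2 (`COc1ccc(S(=O)(=O)c2nc3ccccc3nc2Nc2cccc(N)c2)cc1`) gives 3710 nM as its value, so compound 2 stands within the scatter of the only other measured compound. Compound 3 (`Nc1cccc(Nc2nc3ccccc3nc2S(=O)(=O)c2ccc(Br)cc2)c1`) differs from compound 2 as follows: bromo in place of methoxy on an aromatic carbon (4-methoxyphenyl to 4-bromophenyl, bromo in place of methoxy on an aromatic carbon). For the measured compounds named here, the sole measured step is a 1.7-fold lower number from compound 1 to compound 2 (0.23 log units; within the scatter) and it lies on the aminophenyl group, not at this place. Going by the values given here, no measured compound varies the methoxy group, so the data give neither size nor direction for the change, and no step beyond the scatter is expected in this assay on present evidence. The estimated step is a 1.2-fold lower number from compound 2 to compound 3 (0.09 log units; within the scatter) and it remains poorly constrained. For compound 3 the expected value is 3000 nM with an estimated range from 1000 nM to 9000 nM as the working span.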

Compound 3, half-maximal inhibitory concentration: 3280 nM
Compound 3: middle estimate off by 1.1-fold (0.04 log units), on the low side; the range from low to high includes it.
By their numbers in this assay, from the lowest: compounds 3, 2 and 1 (each within the scatter of the next).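

In this assay, among the compounds shown here, the change from 4-methoxyphenyl to 4-bromophenyl gives a 1.1-fold lower number from compound 2 to compound 3 (0.05 log units; within the scatter) as the first reading at this position, on an aromatic carbon para to a large group. With 3-aminophenyl held constant, bromo therefore takes the place of methoxy with no step beyond the scatter, so this single pair shows no sensitivity to the exchange. Nothing available accounts for this result or links it to a measured property of either group.

As far as these compounds go, whether an amine, a carboxylic acid or a longer alkoxy chain at this place would give a step beyond the scatter remains open. Also open, from the compounds shown here alone, is whether the same exchange would read alike with the 4-aminophenyl group of compound 1 in place of the 3-aminophenyl group.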